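The source may report more compounds than this note shows. Statements on the series, on what has been measured and on what is new or still open speak of the compounds shown alone.

Compound 1 `COc1cccc(-n2cc3nc(-c4cccnc4C)n(C[C@H]4CCCN(CC5CCCCC5)C4)c(=O)c3n2)c1` was tested in an assay on HEK293 cells for displacement of a labelled ligand from growth hormone secretagogue receptor type 1 (Homo sapiens), with a stated time of 60 min (on this read-out lower numbers stand for stronger inhibition and higher numbers for weaker inhibition), where compound 1 gives 200 nM. Within the data shown here, this is the higher of the two numbers recorded so far; the only other measured compound, compound 2 `Cc1ccccc1-c1nc2cn(-c3ccc(Cl)cc3)nc2c(=O)n1CC1CCCN(C(C)C)C1`, gives 0.28 nM in this assay, a value that differs from that of compound 1 by far more than the usual scatter. Among the measured compounds shown here, compound 2 differs from compound 1 in several places at once, so these two values show only that the shared core can reach very low numbers.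

Compound 3 `COc1cccc(-n2cc3nc(-c4cccnc4C)n(C[C@H]4CCCN(CC5CCO5)C4)c(=O)c3n2)c1` is the next compound. It differs from compound 1 in one place: oxetan-2-yl in place of cyclohexyl on a saturated chain carbon bound to an amine nitrogen in a ring. For the measured compounds named here, no measured pair shows this change on its own. For compound 3 a step of a 1.3-fold lower number from compound 1 to compound 3 (0.12 log units; within the scatter) in this assay is expected, small and within the scatter. Compound 3 is estimated at 150 nM in this assay, with a likely range from 30 nM to 800 nM.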

Compound 3, half-maximal inhibitory concentration: 23 nM
For compound 3 the middle estimate is 6.5-fold (0.81 log units) above the measured one, outside the stated range (below it).
By their numbers in this assay, from the lowest: compound 2; then compound 3; then compound 1.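

In this assay, exchanging cyclohexyl for oxetan-2-yl gives an 8.7-fold lower number from compound 1 to compound 3 (0.94 log units; beyond the scatter) with the rest of the molecule unchanged. Among these compounds, this is the first change seen on its own, and it shows that this position affects the read-out and that the smaller, oxygen-containing ring gives stronger inhibition here than cyclohexyl does. Nothing available explains the gain.

The compounds shown leave open whether the step follows from the ring oxygen or the smaller ring, a question that cyclobutyl or tetrahydrofuran-2-yl in the same place could help to separate. On these data alone, it also remains open whether an open chain such as methoxyethyl would serve as well as the oxetan-2-yl ring.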